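This account rests on a few compounds, and the source may have more. Where it says the series, first, only, none or still open, it means among the compounds named here.

Compound 3 `COc1ccc2c(=O)c(/C=C/C(=O)NCc3ccc(C)cc3)coc2c1` gives 14300 nM in a functional assay on Huh-7 cells (Homo sapiens) for inhibition, read by MTT assay, with a stated time of 48 h (on this read-out higher numbers stand for weaker inhibition and lower numbers for stronger inhibition), and stands at the upper end of three numbers that all lie within the scatter of one another: compound 1 `COc1ccc2c(=O)c(/C=C/C(=O)Nc3cc(C)ccc3C)coc2c1` gives 11100 nM and compound 2 `COc1ccc2c(=O)c(/C=C/C(=O)NCc3ccccc3F)coc2c1` gives 8450 nM. Compound 4 `COc1ccc2c(=O)c(/C=C/C(=O)Nc3ccc(F)cc3)coc2c1` differs from compound 3 in one place: 4-fluorophenyl in place of 4-methylbenzyl on an amide-type nitrogen. Within the data shown here, two measured steps bear on this change. The exchange of a directly attached aryl for a benzyl on the amide-type nitrogen, a 1.3-fold higher number from compound 1 to compound 3 (0.11 log units; within the scatter), and the exchange of a fluorophenyl for a methylphenyl on the saturated chain carbon bound to that nitrogen, a 1.7-fold higher number from compound 2 to compound 3 (0.23 log units; within the scatter), both stayed within the scatter. No step beyond the scatter is therefore expected in this assay, a 1.2-fold lower number from compound 3 to compound 4 (0.08 log units; within the scatter). Compound 4 is estimated at 12000 nM, with a range from 5500 nM to 26000 nM.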

Compound 4, half-maximal inhibitory concentration: 33900 nM
The estimate for compound 4 lay 2.8-fold (0.45 log units) below the measured number; measured number above the stated range.
By their numbers in this assay, from the lowest: compounds 2, 1 and 3 (each within the scatter of the next); then compound 4.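

In this assay the amide-type nitrogen first shows a step beyond the scatter with 4-fluorophenyl, giving a 2.4-fold higher number from compound 3 to compound 4 (0.37 log units; beyond the scatter) and a 4.0-fold higher number from compound 2 to compound 4 (0.60 log units; beyond the scatter) as well as a 3.1-fold higher number from compound 1 to compound 4 (0.48 log units; beyond the scatter) in the same direction. A ring attached directly to that nitrogen does not alone mark this weaker inhibition: compound 1 also carries one and stays within the scatter of compound 2 and compound 3. No measured evidence bears on this step.

The compounds shown leave open whether the fluorine or the direct attachment of this ring carries the step. A 4-fluorobenzyl or an unsubstituted phenyl on that nitrogen would tell the two apart.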